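A Fluorophenyl Analogue in the Antiproliferative Series

The compounds below may be only part of what the source reports. "The series", "measured", "known", "first", "only" and "open" are said of these compounds alone.

Compound 1, `COc1ccc2[nH]c(-c3nn4c(COc5ccnc6cc(OC)ccc56)nnc4s3)cc2c1`: in a functional assay on EBC-1 cells (Homo sapiens) for antiproliferative activity, with a stated time of 72 h (a higher number here means a weaker inhibitor, a lower number a stronger inhibitor), compound 1 gives 85.6 nM.
Compound 2, `COc1ccc(-c2nn3c(COc4ccnc5cc(OC)ccc45)nnc3s2)cc1`: in this assay compound 2 gives 161 nM.

Compound 2 stands highest of the two numbers; its nearest neighbour is compound 1, and the step of a 1.9-fold higher number from compound 1 to compound 2 (0.27 log units; within the scatter) lies within the scatter. Compound 3, `COc1ccc2c(OCc3nnc4sc(-c5cccc(F)c5)nn34)ccnc2c1`, differs from compound 2 by 3-fluorophenyl in place of 4-methoxyphenyl on an aromatic carbon. Within the data shown here, no measured step carries this same exchange; the only one known replaced 5-methoxy-1H-indol-2-yl with 4-methoxyphenyl and stayed within the scatter. In this assay, therefore, no step beyond the scatter is expected. Compound 3 is estimated at 200 nM, with a range from 60 nM to 650 nM. This expectation corresponds to a step of a 1.2-fold higher number from compound 2 to compound 3 (0.09 log units; within the scatter).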

Compound 3, half-maximal inhibitory concentration: 504 nM
Beside the measured number, compound 3's estimate is 2.5-fold (0.40 log units) below it, and the stated range covers the measured number.
By their numbers in this assay, from the lowest: compounds 1 and 2 (each within the scatter of the next); then compound 3.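

In this assay, the group on this aromatic carbon of the five-membered ring can move the number beyond the scatter, which the earlier exchange did not show: 3-fluorophenyl in place of 4-methoxyphenyl gives (a 3.1-fold higher number from compound 2 to compound 3 (0.50 log units; beyond the scatter)). In place of 5-methoxy-1H-indol-2-yl, the same group gives a larger step (a 5.9-fold higher number from compound 1 to compound 3 (0.77 log units; beyond the scatter)). Nothing available here accounts for either step.

The compounds shown leave open whether removing the methoxy group or adding the fluorine matters more. They also leave open how a phenyl ring bearing an amine or a carboxylic acid would read at this carbon.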